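A few compounds are considered here, and "the series" means these few. Any claim that something is new, unique, unknown or untested is made for them only; others in the source may bear on it.

Measured so far in a functional assay on Capan-2 cells (Homo sapiens) for inhibition, read by MTT assay, with a stated time of 72 h; on this read-out lower numbers stand for stronger inhibition of growth and higher numbers for weaker inhibition of growth:
compound 1 `O=S(=O)(NCCCNCc1cccc2ccccc12)c1cc(C(F)(F)F)cc(C(F)(F)F)c1`, 2700 nM
compound 2 `O=S(=O)(NCCCNCc1ccc(Cl)cc1)c1cc(C(F)(F)F)cc(C(F)(F)F)c1`, 2700 nM
compound 3 `CN(CCCNS(=O)(=O)c1cc(C(F)(F)F)cc(C(F)(F)F)c1)Cc1ccccc1`, 46000 nM

In this assay compound 3 gives the highest of the three numbers; its gaps to compound 1 and to compound 2 are beyond the scatter, as the step of a 17-fold higher number from compound 2 to compound 3 (1.23 log units; beyond the scatter) shows. Compound 4 `O=S(=O)(NCCCNCc1ccccc1)c1cc(C(F)(F)F)cc(C(F)(F)F)c1` differs from compound 3 by hydrogen in place of methyl on an amine nitrogen. The step of a 17-fold higher number from compound 2 to compound 3 (1.23 log units; beyond the scatter) bears on this change most directly, as it replaced the (4-chlorobenzyl)amino group of compound 2 with the benzyl(methyl)amino of compound 3; the step of no change at the digits printed from compound 1 to compound 2 (within the scatter) shows that exchanging the aryl part alone left the number unchanged. Removing the methyl is therefore expected to undo most of that rise, an expected step of a 15-fold lower number from compound 3 to compound 4 (1.19 log units; beyond the scatter). Compound 4 is thus estimated at 3000 nM, within 1200 nM to 8000 nM.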

Compound 4, concentration for 50% growth inhibition: 14000 nM
The estimate for compound 4 lay 4.7-fold (0.67 log units) below the measured number; measured number outside the range, above it.
By their numbers in this assay, from the lowest: compounds 1 and 2 (each within the scatter of the next); then compound 4; then compound 3.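

In this assay, hydrogen in place of methyl on the amine nitrogen gives a 3.3-fold lower number from compound 3 to compound 4 (0.52 log units; beyond the scatter), so this change recovers only part of the gap left by the earlier step. The aryl part also matters here, though exchanging it between the earlier pair changed nothing: hydrogen in place of chloro on an aromatic carbon gives a 5.2-fold higher number from compound 2 to compound 4 (0.71 log units; beyond the scatter), and phenyl in place of naphthalen-1-yl gives a 5.2-fold higher number from compound 1 to compound 4 (0.71 log units; beyond the scatter). Nothing available explains these steps. Open remain an ethyl on that amine nitrogen, and a fluoro in place of that chloro.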